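Thiophene in place of fluorophenyl on a nucleoside scaffold

The source may hold more compounds than are shown below. What is called first, only, known or untested is meant among the compounds shown, and "the series" means these compounds.

Compound 1 `Nc1ncnn2c([C@@H]3O[C@H](CO)[C@@H](O)[C@H]3O)cc(-c3ccc(F)cc3)c12`: 42500 nM
Compound 2 `COc1ccc(-c2cc([C@@H]3O[C@H](CO)[C@@H](O)[C@H]3O)n3ncnc(N)c23)cc1`: 47100 nM
Compound 3 `Nc1ncnn2c([C@@H]3O[C@H](CO)[C@@H](O)[C@H]3O)cc(/C=C/c3ccccc3)c12`: 4800 nM

In a functional assay on HCT-116 cells (Homo sapiens) for antiproliferative activity, with a stated time of 72 h (on this read-out higher numbers stand for weaker inhibition and lower numbers for stronger inhibition), compound 1 gives 42500 nM, and compound 2 sits within the scatter of it, as a 1.1-fold higher number from compound 1 to compound 2 (0.04 log units; within the scatter) shows; compound 3 gives a clearly lower number, as an 8.9-fold lower number from compound 1 to compound 3 (0.95 log units; beyond the scatter) shows. Compound 4 `Nc1ncnn2c([C@@H]3O[C@H](CO)[C@@H](O)[C@H]3O)cc(-c3ccsc3)c12` differs from compound 1 by thiophen-3-yl in place of 4-fluorophenyl on an aromatic carbon. For the measured compounds named here, no measured step swaps the aromatic ring itself for another; the only step that touches the same aromatic ring, a 1.1-fold higher number from compound 1 to compound 2 (0.04 log units; within the scatter), lay within the scatter, while the larger change in a 9.8-fold lower number from compound 2 to compound 3 (0.99 log units; beyond the scatter) was modest. A step close to the scatter is therefore expected, with a slight lean toward a lower number, giving the expected 1.4-fold lower number from compound 1 to compound 4 (0.15 log units; within the scatter). For compound 4 the estimate in this assay is 30000 nM, between 8000 nM and 100000 nM.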

Compound 4, half-maximal inhibitory concentration: 45200 nM
For compound 4 the middle estimate is 1.5-fold (0.18 log units) below the measured one; measured number inside the range.
By their numbers in this assay, from the lowest: compound 3; then compounds 1, 4 and 2 (each within the scatter of the next).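

In this assay, thiophen-3-yl at this position, a five-membered aromatic ring carrying sulfur, reads the same as the six-membered 4-fluorophenyl ring (a 1.1-fold higher number from compound 1 to compound 4 (0.03 log units; within the scatter)) and the 4-methoxyphenyl ring (a 1.0-fold lower number from compound 2 to compound 4 (0.02 log units; within the scatter)). Among these compounds, then, swapping the aromatic ring itself, and not only its substituent, leaves the number within the scatter, while 2-phenylethenyl alone stands apart (a 9.4-fold higher number from compound 3 to compound 4 (0.97 log units; beyond the scatter)). Nothing available explains this pattern. Going by these compounds, whether an aminophenyl group, a carboxylic acid or a longer chain at this position would give a number like that of compound 3 stays open.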